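The compounds below may be only part of what the source reports. "The series", "measured", "known", "first", "only" and "open" are said of these compounds alone.

Values measured in a functional assay on MCF7 cells (Homo sapiens) for inhibition, read by MTT assay, with a stated time of 48 h; a higher number here means a weaker inhibitor, a lower number a stronger inhibitor:

Compound 1 `Brc1ccc2[nH]cc(C(c3c[nH]c4ccc(Br)cc34)C3CCCCC3)c2c1`: 4100 nM
Compound 2 `O=[N+]([O-])c1ccc2[nH]cc(C(c3ccc(Cl)cc3)c3c[nH]c4ccc([N+](=O)[O-])cc34)c2c1`: > 100000 nM

For compound 2, > 100000 nM is a limit of the assay and not a number.

Compound 3 `O=[N+]([O-])c1ccc(C(c2c[nH]c3ccc([N+](=O)[O-])cc23)c2c[nH]c3ccc([N+](=O)[O-])cc23)cc1` differs from compound 2 by having nitro in place of chloro on an aromatic carbon, para to a large group, so that 4-chlorophenyl becomes 4-nitrophenyl (nitro in place of chloro on an aromatic carbon). Going by the values given here, no measured pair shows this change. In this assay, no shift in either direction beyond the usual scatter is expected, and the estimated move is a number no higher from compound 2 to compound 3 (the limit leaves the size open). For compound 3 the expected value is 100000 nM, with an estimated range from 30000 nM to 300000 nM.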

Compound 3, half-maximal inhibitory concentration: 22500 nM
Beside the measured number, compound 3's estimate is 4.4-fold (0.65 log units) above it; measured number outside the range, below it.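

In this assay, nitro in place of chloro on an aromatic carbon, para to a large group, gives an at least 4.4-fold lower number from compound 2 to compound 3 (0.64 log units; beyond the scatter). Going by these compounds alone, this shows that the group at this place can shift the read-out, which the earlier compounds could not show. The step can be given only as a minimum because compound 2 stands at a limit of the assay and not at a number: the limit of > 100000 nM in this assay, at which 1 of the 3 values shown sits.

On these data alone, how an amine or a carboxylic acid at this place would read remains open. So does whether the same change would give a similar step on the core of compound 1.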